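The source may report more compounds than this note shows. Statements on the series, on what has been measured and on what is new or still open speak of the compounds shown alone.

Among the measured compounds shown here, compound 2 `CCCCNc1nc2c(ncn2-c2ccccc2)c(=O)n1-c1ccc(Cl)cc1` is the only member of the series with a number rather than a limit in a functional assay on KB cells (Homo sapiens) for cytotoxicity, read by MTT assay, with a stated time of 72 h (a higher number here means a weaker inhibitor, a lower number a stronger inhibitor), where compound 2 gives 37700 nM. Compound 1 `CNc1nc2c(ncn2-c2ccccc2)c(=O)n1-c1ccc(Cl)cc1` reaches only a limit in this assay, > 100000 nM, which is the limit of > 100000 nM in this assay, at which 1 of the 2 values shown sits. For the measured compounds named here, the single measured step, an at least 2.6-fold lower number from compound 1 to compound 2 (0.42 log units; beyond the scatter), puts propyl in place of hydrogen on the saturated chain carbon bound to the nitrogen on the aromatic ring, and it is rated at least modest.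

Compound 3 `O=c1c2ncn(-c3ccccc3)c2nc(NCc2ccccc2)n1-c1ccc(Cl)cc1` carries the change (phenyl in place of propyl on a saturated chain carbon bound to a nitrogen on an aromatic ring); cut one bond further out, this reads butyl to benzyl. Going by the values given here, only the one step above bears on it, and it shows that growing the group on this chain carbon lowered the number beyond the scatter; whether phenyl in place of propyl continues that trend is untested. The step expected is a 1.9-fold lower number from compound 2 to compound 3 (0.28 log units; within the scatter), small and possibly within the scatter. In this assay compound 3 is expected to give 20000 nM, with a range from 7000 nM to 60000 nM.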

Compound 3, half-maximal inhibitory concentration: 34300 nM
Compound 3: the middle estimate sits 1.7-fold (0.23 log units) below what was measured, within the range that was stated.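

Phenyl in place of propyl on the saturated chain carbon bound to the nitrogen on the aromatic ring gives a 1.1-fold lower number from compound 2 to compound 3 (0.04 log units; within the scatter) in this assay, so butylamino and benzylamino cannot be told apart here, and this position accepts an aromatic ring as well as an open chain. Phenyl in place of hydrogen at the same carbon gives an at least 2.9-fold lower number from compound 1 to compound 3 (0.46 log units; beyond the scatter), which matches the earlier step with propyl in direction. Compound 1 stands at a limit and not at a number, so the true size of both steps from it stays unknown: the limit of > 100000 nM in this assay, at which 1 of the 3 values shown sits.

Open, on these data alone, is whether a longer chain than butyl, or an amine or a carboxylic acid at the end of this group, would separate from compound 2 and compound 3 beyond the scatter. Also open, as far as these compounds go, is whether a substituted benzyl would do so.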